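Shortening the nitrile chain on the second core

The source may hold more compounds than are shown below. What is called first, only, known or untested is meant among the compounds shown, and "the series" means these compounds.

Compound 1, `CC(C)(N)C(=O)N[C@H](COCc1ccccc1)c1nnnn1CCCCC#N`, gives 35 nM in a functional assay on H4 cells for agonist activity at growth hormone secretagogue receptor type 1 (Homo sapiens), read by FLIPR; on this read-out lower numbers stand for an effect already at smaller amounts and higher numbers for an effect only at larger amounts of compound.
Compound 2, `CC(C)(N)C(=O)N[C@H](COCc1ccccc1)c1nnnn1CC#N`, gives 29 nM in this assay.
Compound 3, `CC(C)(N)C(=O)N[C@H](COCc1ccccc1)c1nnn(CCCCC#N)n1`, gives 1860 nM in this assay.

Compound 3 has the same atoms as compound 1, joined differently; the difference between the two cores is not broken down here. Its number stands far above those of compounds 1 and 2, and both gaps lie beyond the usual scatter.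

Compound 4, `CC(C)(N)C(=O)N[C@H](COCc1ccccc1)c1nnn(CC#N)n1`, has not been measured. It differs from compound 3 by cyano in place of 3-cyanopropyl on a saturated chain carbon bound to an aromatic nitrogen. The same change, (cyano in place of 3-cyanopropyl on a saturated chain carbon bound to an aromatic nitrogen), has been made once before, on the core of compound 1, where it produced a 1.2-fold lower number from compound 1 to compound 2 (0.08 log units; within the scatter). The place of the change is described in the same words for both pairs, so this counts as the same change.

On the core of compound 3 the step is expected to be of the same small size, a 1.2-fold lower number from compound 3 to compound 4 (0.09 log units; within the scatter), because of a 1.2-fold lower number from compound 1 to compound 2 (0.08 log units; within the scatter). Compound 4 is therefore estimated at 1500 nM in this assay, most likely between 600 nM and 4000 nM.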

Compound 4, half-maximal effective concentration: 1520 nM
Beside the measured number, compound 4's estimate is 1.0-fold (0.01 log units) below it; low and high end bracket the measured number.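

In this assay the shorter chain gives a 1.2-fold lower number from compound 3 to compound 4 (0.09 log units; within the scatter), and this step matches the one on the other core: the same change on two cores in this assay, a 1.2-fold lower number (0.08 log units; within the scatter) from compound 1 to compound 2 and a 1.2-fold lower number (0.09 log units; within the scatter) from compound 3 to compound 4, 1.0-fold (0.01 log units) apart, within the scatter of two such steps

For these two cores, then, the change carries over at the same small size, and the shorter chain leaves the number within the scatter on both. It does not close the gap between the cores, which remains at a 52-fold higher number from compound 2 to compound 4 (1.72 log units; beyond the scatter), and two pairs sharing a single change cannot show that it would carry to a further core or explain why the two cores stand so far apart.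

The compounds shown hold only nitrile-ending chains at this place, so it stays open whether an amine, a carboxylic acid or a chain longer than 4-cyanobutyl would also behave alike on both cores. As far as these compounds go, it also stays open whether any such group could bring the core of compound 3 close to the level of compound 2.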